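Fluoro Swapped for Chloro on a Second Core

The source may report more compounds than this note shows. Statements on the series, on what has been measured and on what is new or still open speak of the compounds shown alone.

Measured so far, all in the same assay:
Compound 1, `O=S(=O)(Nc1ccc(Cl)cc1)c1ccc(Cl)cc1`: 8.3
Compound 2, `O=S(=O)(Nc1ccc(F)cc1)c1ccc(Cl)cc1`: 8.41
Compound 3, `Cc1ccc(NS(=O)(=O)c2ccc(F)cc2)cc1`: 9.23

These numbers come from an ADME assay. Compounds 1 and 2 share a core and differ in one place only: chloro in place of fluoro on an aromatic carbon. That change gave a number 0.11 log units lower from compound 2 to compound 1 (within the scatter), so for practical purposes the two compounds behave alike here. Compound 3 sits on a different core; how its core differs from that of compound 2 is not broken down here. Its number stands apart from both others, beyond the scatter from compound 2 and from compound 1.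

Compound 4, `Cc1ccc(NS(=O)(=O)c2ccc(Cl)cc2)cc1`, is not yet measured. Going by the values given here, it comes from compound 3 by chloro in place of fluoro on an aromatic carbon, the same change as the one from compound 2 to compound 1. Among the compounds with values here, the only guide is that earlier step, a number 0.11 log units lower from compound 2 to compound 1 (within the scatter), which stayed within the scatter. For compound 4 the expected step is a number 0.13 log units lower from compound 3 to compound 4 (within the scatter), a small one, because the matching step a number 0.11 log units lower from compound 2 to compound 1 (within the scatter) on the other core was small. Compound 4 is therefore expected to give 9.1, most likely between 8.8 and 9.4.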

Compound 4, acid dissociation constant: 8.78
Compound 4: middle estimate off by 0.32 log units, on the high side, outside the stated range (below it).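

In this assay, chloro in place of fluoro on the core of compound 3 gave a number 0.45 log units lower from compound 3 to compound 4 (beyond the scatter), which is a clearer shift than the one seen on the core of compound 1. Even so, the two results do not truly disagree, since both steps run the same way and the gap between them is no larger than such steps can scatter: the same change on two cores in this assay, a number 0.11 log units lower (within the scatter) from compound 2 to compound 1 and a number 0.45 log units lower (beyond the scatter) from compound 3 to compound 4, 0.34 log units apart, within the scatter of two such steps This shows that the change has carried over in direction on these two cores, but a single pair on each core cannot fix the size of the step or show whether the core alters it.

Methyl in place of fluoro gave a number 0.37 log units higher from compound 2 to compound 4 (beyond the scatter) and methyl in place of chloro gave a number 0.48 log units higher from compound 1 to compound 4 (beyond the scatter), yet each of these steps is seen only once here. The compounds shown leave open how a different group on that aromatic carbon, such as an amine or a nitrile, would move the number on either core.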